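Turning two ring carbons in compound 1

The source may hold more compounds than are shown below. What is called first, only, known or untested is meant among the compounds shown, and "the series" means these compounds.

Measured in a functional assay on HT-29 cells (Homo sapiens) for cytotoxicity, read by sulforhodamine B assay (a lower number here means a stronger inhibitor of growth, a higher number a weaker inhibitor of growth), so far:
- compound 1 `O=C(NCCCCCNC(=O)C1=NO[C@]2(C=C(Br)C(=O)[C@@H](Br)[C@@H]2O)C1)C1=NO[C@]2(C=C(Br)C(=O)[C@@H](Br)[C@@H]2O)C1` gives (1500 nM)
- compound 2 `COC1=C(Br)[C@H](O)[C@@]2(C=C1Br)CC(C(=O)NCCCCNC(=O)C1=NO[C@]3(C=C(Br)C(=O)[C@@H](Br)[C@@H]3O)C1)=NO2` gives (4100 nM)
- compound 3 `COC1=C(Br)[C@H](O)[C@@]2(C=C1Br)CC(C(=O)NCCCCCNC(=O)C1=NO[C@]3(C=C(Br)C(OC)(OC)[C@@H](Br)[C@@H]3O)C1)=NO2` gives (4800 nM)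

Compound 1 has the lowest number of the three, and its steps to compound 2 and compound 3 both lie beyond the scatter. Compound 4 `O=C(NCCCCCNC(=O)C1=NO[C@]2(C=C(Br)C(=O)[C@H](Br)[C@@H]2O)C1)C1=NO[C@]2(C=C(Br)C(=O)[C@H](Br)[C@@H]2O)C1` has the same atoms and bonds as compound 1 and differs only in configuration as drawn (the two compounds have the same atoms and bonds and differ only in configuration as drawn: 2 of 6 stereo elements differ; a stereocentre at a saturated ring carbon is drawn S in compound 1 and R in compound 4; a stereocentre at a saturated ring carbon is drawn S in compound 1 and R in compound 4). Among the measured compounds shown here, at two saturated ring carbons, S becomes R. No measured pair shows what such a change does in this assay, so the expectation is uncertain. A moderate loss beyond the scatter is expected, as compound 1 (1500 nM) already stands lowest. The estimated change is a weaker inhibitor (a 2.3-fold higher number from compound 1 to compound 4 (0.37 log units; beyond the scatter)). For compound 4 the estimated value is 3500 nM (expected range 1000 nM to 12000 nM).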

Compound 4, concentration for 50% growth inhibition: 1600 nM
Compound 4: middle estimate off by 2.2-fold (0.34 log units), on the high side; the range from low to high includes it.
By their numbers in this assay, from the lowest: compounds 1 and 4 (each within the scatter of the next); then compounds 2 and 3 (each within the scatter of the next).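

In this assay, turning the two saturated ring carbons from S to R gives a 1.1-fold higher number from compound 1 to compound 4 (0.03 log units; within the scatter). The two compounds therefore cannot be told apart in this assay, so the drawn configuration at these two carbons shows no measurable effect on growth inhibition here. No earlier pair could show this, but this one isolates configuration alone: the fact that compounds 1 and 4 differ only in the configuration as drawn

Still open, going by these compounds, is whether changing only one of these carbons would give the same result. Also open, on these data alone, is what a longer chain or an added amine would do.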